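The source may hold more compounds than are shown below. What is called first, only, known or untested is meant among the compounds shown, and "the series" means these compounds.

Working notes on the series. In a functional assay on cells (Homo sapiens) for inhibition, read by MTT assay, with a stated time of 48 h (on this read-out lower numbers stand for stronger inhibition and higher numbers for weaker inhibition), compound 1 (`O=C(CCCOc1no[n+]([O-])c1S(=O)(=O)c1ccccc1)NO`) gives 22000 nM and compound 2 (`O=C(CCCCOc1no[n+]([O-])c1S(=O)(=O)c1ccccc1)NO`) gives 4300 nM. Going by the values given here, the one measured step is a 5.1-fold lower number from compound 1 to compound 2 (0.71 log units; beyond the scatter), with (hydroxycarbamoyl)methyl in place of hydroxycarbamoyl on a saturated chain carbon.

For compound 3 (`O=C(CCCCCCCOc1no[n+]([O-])c1S(=O)(=O)c1ccccc1)NO`) the entry reads "not determined" (no result reported), so it has no position on the numbers and offers no value to step from.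

Compound 4 (`O=C(COCCOc1no[n+]([O-])c1S(=O)(=O)c1ccccc1)NO`) has (hydroxycarbamoyl)methoxy in place of 5-(hydroxycarbamoyl)pentyl on a saturated chain carbon, two bonds along the chain from an oxygen on an aromatic ring.

No size or direction can be given for this change itself, since one end of it has no number. Among the compounds with values here, the only measured step concerns a different change, and it bears on compound 4 only indirectly, as a modest step beyond the scatter that shows how far one chain change has moved this assay. The working anchor is therefore compound 2 at 4300 nM, the measured structure nearest to compound 4. Within the data shown here, a somewhat weaker number than that anchor is expected, with a wide margin, as the oxygen in the chain has no measured precedent here.

Compound 4 is expected at about 7000 nM, with an estimated range of 1800 nM to 27000 nM.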

Compound 4, half-maximal inhibitory concentration: 19800 nM
Beside the measured number, compound 4's estimate is 2.8-fold (0.45 log units) below it; low and high end bracket the measured number.
By their numbers in this assay, from the lowest: compound 2; then compounds 4 and 1 (each within the scatter of the next).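

In this assay, (hydroxycarbamoyl)methoxy in place of 2-(hydroxycarbamoyl)ethyl on a saturated chain carbon, two bonds along the chain from an oxygen on an aromatic ring, gives a 4.6-fold higher number from compound 2 to compound 4 (0.66 log units; beyond the scatter), so the earlier modest step of a 5.1-fold lower number from compound 1 to compound 2 (0.71 log units; beyond the scatter) does not carry over to a chain holding this oxygen. Against (hydroxycarbamoyl)methyl at the same place, (hydroxycarbamoyl)methoxy gives a 1.1-fold lower number from compound 1 to compound 4 (0.05 log units; within the scatter), which leaves compound 1 and compound 4 inseparable and sets compound 2 apart from both as the one measured compound with a lower number. No measured evidence accounts for these differences.

As far as these compounds go, the change from compound 3 to compound 4 cannot be read, so how a longer chain of carbons alone behaves at this position stays open, as does whether any chain beyond that of compound 2 brings the number lower. Also open, from the compounds shown here alone, are a chain carrying an amine or a sulfur atom in place of the chain oxygen, and a carboxylic acid in place of the hydroxycarbamoyl group on the chain of compound 2.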